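Chloro added to the amide aryl of compound 2

A few compounds are considered here, and "the series" means these few. Any claim that something is new, unique, unknown or untested is made for them only; others in the source may bear on it.

Compound 2 `COc1cc(-c2nn(-c3cccc(NC(=O)c4cccc(C(F)(F)F)c4)c3)cc2-c2ccncc2)ccc1Cl` stands highest of the three numbers in a functional assay on UACC-257 cells (Homo sapiens) for inhibition, read by sulforhodamine B assay, with a stated time of 48 h (a lower number here means a stronger inhibitor of growth, a higher number a weaker inhibitor of growth), giving 27900 nM. Compound 1 `O=C(Nc1cccc(-n2cc(-c3ccncc3)c(-c3ccc(Cl)c(O)c3)n2)c1)Nc1cccc(C(F)(F)F)c1` gives 4340 nM and compound 3 `O=C(Nc1cccc(-n2cc(-c3ccncc3)c(-c3ccc(Cl)c(O)c3)n2)c1)Nc1ccc(Cl)c(Cl)c1` gives 930 nM. Going by the values given here, the one single-point step measured so far, a 4.7-fold lower number from compound 1 to compound 3 (0.67 log units; beyond the scatter), places 3,4-dichlorophenyl in place of 3-(trifluoromethyl)phenyl on an amide-type nitrogen. Compound 4 `COc1cc(-c2nn(-c3cccc(NC(=O)c4ccc(Cl)c(C(F)(F)F)c4)c3)cc2-c2ccncc2)ccc1Cl` differs from compound 2 by chloro in place of hydrogen on an aromatic carbon, so that 3-(trifluoromethyl)phenyl becomes 4-chloro-3-(trifluoromethyl)phenyl. The step from compound 1 to compound 3 bears on this only loosely: it also swaps trifluoromethyl for chloro, and the linkage in compound 2 is not that of compound 1. A modest decrease is therefore expected for compound 4, a 2.8-fold lower number from compound 2 to compound 4 (0.45 log units; beyond the scatter). Compound 4 is estimated at 10000 nM, within 3000 nM to 30000 nM.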

Compound 4, concentration for 50% growth inhibition: 7130 nM
Beside the measured number, compound 4's estimate is 1.4-fold (0.15 log units) above it; measured number inside the range.
By their numbers in this assay, from the lowest: compound 3; then compounds 1 and 4 (each within the scatter of the next); then compound 2.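

In this assay chloro in place of hydrogen on an aromatic carbon, ortho to the trifluoromethyl group and para to a large group, gives a 3.9-fold lower number from compound 2 to compound 4 (0.59 log units; beyond the scatter) and so shows that this position of the amide aryl accepts an added group with a lower number. Unlike the earlier step on the same aryl, this change keeps the trifluoromethyl group and reads the chloro alone. Nothing available explains the size of this step.

Going by these compounds, whether an amine or a carboxylic acid at this position would give a similar step remains open. Also open, on these data alone, is whether chloro gives the same step on the aryl of compound 1, whose linkage differs.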